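The source may report more compounds than this note shows. Statements on the series, on what has been measured and on what is new or still open speak of the compounds shown alone.

Values in a functional assay on HCT-116 cells (Homo sapiens) for antiproliferative activity, read by MTT assay, with a stated time of 24 h; on this read-out higher numbers stand for weaker inhibition and lower numbers for stronger inhibition:

- compound 1 `COc1cc(OC)c(-c2coc3cc(OCC=C(C)C)ccc3c2=O)cc1OC`: 680 nM
- compound 2 `COc1cccc(C(=O)Oc2ccc3c(=O)c(-c4cc(OC)c(OC)cc4OC)coc3c2)c1`: > 10000 nM (a limit)
- compound 3 `COc1cc(OC)c(-c2coc3cc(OCC(=O)c4cccc(C(F)(F)F)c4)ccc3c2=O)cc1OC`: > 10000 nM (a limit)
- compound 4 `COc1cc(OC)c(-c2coc3cc(OCc4ccc(C#N)cc4)ccc3c2=O)cc1OC`: not yet measured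

Compound 3 stands at the limit of > 10000 nM in this assay, at which 2 of the 3 values shown sit. This is a limit and not a number, so the true size of any step away from compound 3 cannot be fixed.

The next change is 4-cyanophenyl in place of (3-(trifluoromethyl)phenyl)carbonyl on a saturated chain carbon bound to an oxygen on an aromatic ring. The aromatic ring stays, while the carbonyl and the trifluoromethyl group go.

Among the compounds with values here, two measured steps bear on this. The first is an at least 14-fold higher number from compound 1 to compound 3 (1.16 log units; beyond the scatter), and the second is an at least 14-fold higher number from compound 1 to compound 2 (1.16 log units; beyond the scatter). Both are large and beyond the scatter, and both replace the 3-methylbut-2-en-1-yl end of compound 1 with a group carrying an aromatic ring. Compound 4 also carries such a ring, but neither step tests a ring without the carbonyl, so the read-across is partial.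

In this assay, within the data shown here, no large step is therefore expected, though a modest move to lower numbers remains possible. The expected step is an at least 1.1-fold lower number from compound 3 to compound 4 (0.04 log units; that floor lies within the scatter). For compound 4 the estimated value is 9000 nM, with an expected range of 2500 nM to 30000 nM.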

Compound 4, half-maximal inhibitory concentration: 4220 nM
The estimate for compound 4 lay 2.1-fold (0.33 log units) above the measured number, within the range that was stated.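

In this assay, compound 4 is the only one shown with an aromatic ring in place of the 3-methylbut-2-en-1-yl end that gives a number rather than a limit, so a ring at this place does not by itself carry the value to the limit reached by compound 2 and compound 3: the limit of > 10000 nM in this assay, at which 2 of the 4 values shown sit.

Swapping (3-(trifluoromethyl)phenyl)carbonyl for 4-cyanophenyl on the saturated chain carbon gives an at least 2.3-fold lower number from compound 3 to compound 4 (0.37 log units; beyond the scatter), and swapping (3-methoxyphenyl)carbonyl for 4-cyanobenzyl on the oxygen gives an at least 2.3-fold lower number from compound 2 to compound 4 (0.37 log units; beyond the scatter); both are floors set by limits, so their true sizes remain unknown. The ring still does not match the original end, with a 6.2-fold higher number from compound 1 to compound 4 (0.79 log units; beyond the scatter).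

The carbonyl and the trifluoromethyl group leave together while the nitrile enters, so the compounds shown cannot assign the step from compound 3 to any one of these changes. Going by these compounds, it also remains open whether an amine or a carboxylic acid on the ring, or a longer chain between the ring and the oxygen, would bring the value nearer to that of compound 1.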